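From 4-bromophenyl to 3-methylphenyl on the shared core

This account rests on a few compounds, and the source may have more. Where it says the series, first, only, none or still open, it means among the compounds named here.

Values so far in a functional assay on NCI-H460 cells (Homo sapiens) for antiproliferative activity, read by MTT assay, with a stated time of 48 h (on this read-out higher numbers stand for weaker inhibition and lower numbers for stronger inhibition), are these
Compound 1 `COc1cccc(-c2nc3cccc(-c4cc(OC)c(OC)c(OC)c4)c3o2)c1` gives > 25000 nM as a limit
Compound 2 `COc1cc(-c2cccc3nc(-c4cccc(F)c4)oc23)cc(OC)c1OC` gives 3300 nM
Compound 3 `COc1cc(-c2cccc3nc(-c4ccc(Br)cc4)oc23)cc(OC)c1OC` gives > 25000 nM as a limit

Compound 3 stands on the limit of > 25000 nM in this assay, at which 2 of the 3 values shown sit, with its own limit (> 25000 nM). Compound 4 `COc1cc(-c2cccc3nc(-c4cccc(C)c4)oc23)cc(OC)c1OC` has 3-methylphenyl in place of 4-bromophenyl on an aromatic carbon. Among the compounds with values here, two measured steps bear on this change. The first (an at least 7.5-fold higher number from compound 2 to compound 3 (0.87 log units; beyond the scatter)) leaves 3-fluorophenyl for 4-bromophenyl. The second (an at least 7.5-fold lower number from compound 1 to compound 2 (0.87 log units; beyond the scatter)) shows that 3-methoxyphenyl does not behave like 3-fluorophenyl, so compound 1 goes against any simple rule. A third step gives no size (a step that the two limits leave unreadable from compound 1 to compound 3). A lower number of modest size is therefore expected in this assay for compound 4, though it may stay at the limit. The estimated step is (an at least 3.5-fold lower number from compound 3 to compound 4 (0.55 log units; beyond the scatter)). The estimated value for compound 4 is 7000 nM (expected range 2000 nM to 25000 nM).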

Compound 4, half-maximal inhibitory concentration: > 25000 nM
Compound 4: no number, only a limit; the forecaster's own chance of this, stated with the estimate: 30%; middle value at least 3.5-fold (0.55 log units) away from the limit.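

In this assay compound 4 gives > 25000 nM, which is a limit and not a number. Methyl in place of fluoro gives an at least 7.5-fold higher number from compound 2 to compound 4 (0.87 log units; beyond the scatter), so 3-methylphenyl joins the 3-methoxyphenyl of compound 1 in not matching 3-fluorophenyl. The steps from compound 1 and compound 3 to compound 4 cannot be read, and compound 2 alone stands apart from the shared limit: the limit of > 25000 nM in this assay, at which 3 of the 4 values shown sit.

The compounds shown leave open whether fluoro is the only group on this phenyl ring that gives a number in this assay. A chloro, a nitrile or an amine in its place could test this.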